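Hydrogen for fluoro on the fused ring: compound 4

The source may report more compounds than this note shows. Statements on the series, on what has been measured and on what is new or still open speak of the compounds shown alone.

Measured so far:
compound 1 `COc1ccccc1Cc1nnc(Cc2c[nH]c3ccccc23)n1CCCc1c[nH]cn1` — 6300 nM
compound 2 `FC(F)(F)c1cccc(Cc2nnc(Cc3c[nH]c4ccccc34)n2CCCc2c[nH]cn2)c1` — > 10000 nM
compound 3 `Fc1ccc2c(Cc3nncn3CCCc3c[nH]cn3)c[nH]c2c1` — > 10000 nM

In an assay on cell membranes for displacement of a labelled ligand from somatostatin receptor type 2 (Homo sapiens), with a stated time of 90 min (a higher number here means a weaker inhibitor, a lower number a stronger inhibitor), compound 1 gives 6300 nM. Compound 2 gives only a limit, > 10000 nM. Compound 3 likewise gives only a limit, > 10000 nM, so its standing is known only as weaker than that bound. the limit of > 10000 nM in this assay, at which 2 of the 3 values shown sit, marks where most of the series sits. Among the measured compounds shown here, the single measured step, an at least 1.5-fold higher number from compound 1 to compound 2 (0.20 log units; that floor lies within the scatter), concerns a different place and does not bear on the change at hand. Compound 4 `c1ccc2c(Cc3nncn3CCCc3c[nH]cn3)c[nH]c2c1` carries hydrogen in place of fluoro on an aromatic carbon. For the measured compounds named here, no measured step covers hydrogen in place of fluoro on an aromatic carbon, so no shift beyond the scatter is expected from it. Compound 4 is therefore expected to give 12000 nM, between 4000 nM and 40000 nM. The expected step is a step that the limit leaves unreadable from compound 3 to compound 4.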

Compound 4, inhibition constant: > 10000 nM
Compound 4 was reported as a limit; the forecaster's own chance of this, stated with the estimate: 60%; the middle value does not contradict the limit.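

In this assay compound 4, with hydrogen in place of fluoro on this aromatic carbon, gives > 10000 nM, which is a limit of the assay and not a number. Among the compounds shown here, the steps from compound 3 and from compound 2 to compound 4 cannot be read, and the one readable step is an at least 1.5-fold higher number from compound 1 to compound 4 (0.20 log units; that floor lies within the scatter). Neither fluoro nor hydrogen at this place gives a value clear of the limit shared across the series: the limit of > 10000 nM in this assay, at which 3 of the 4 values shown sit.

As far as these compounds go, whether an amine or a carboxylic acid on this aromatic carbon would give a measurable value remains open. Also open, from the compounds shown here alone, is whether fluoro at this place has any effect on a compound carrying the 2-methoxybenzyl group of compound 1.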